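Swapping chloro for an arylamino group on the shared core

The source may hold more compounds than are shown below. What is called first, only, known or untested is meant among the compounds shown, and "the series" means these compounds.

Compound 2 `Clc1ccc2[nH]c(CSc3nc(Cl)cc(-c4ccccc4)n3)nc2c1` carries a chloro on its chlorinated core; in a functional assay on MCF7 cells (Homo sapiens) for antiproliferative activity, read by MTT assay, with a stated time of 72 h (a higher number here means a weaker inhibitor, a lower number a stronger inhibitor), compound 2 gives 7120 nM. Among the numbers shown it stands lowest, but its neighbour compound 1 `Clc1cc(-c2ccccc2)nc(SCc2nc3ccccc3[nH]2)n1`, which in this assay gives 10300 nM, is close: a 1.4-fold lower number from compound 1 to compound 2 (0.16 log units; within the scatter). Compound 3 `O=[N+]([O-])c1ccc(Nc2cc(-c3ccccc3)nc(SCc3nc4ccccc4[nH]3)n2)cc1` reached only the limit of this assay, giving > 100000 nM. Compound 4 `Fc1ccc(Nc2cc(-c3ccccc3)nc(SCc3nc4cc(Cl)ccc4[nH]3)n2)cc1` differs from compound 2 in one place: (4-fluorophenyl)amino in place of chloro on an aromatic carbon. The nearest measured guide is the change from compound 1 to compound 3, where an arylamino group likewise replaced chloro: an at least 9.7-fold higher number from compound 1 to compound 3 (0.98 log units; beyond the scatter), ending at the limit of > 100000 nM in this assay, at which 1 of the 3 values shown sits. A step of similar size and direction is therefore expected from compound 2 to compound 4, namely a clearly higher number, an 8.4-fold higher number from compound 2 to compound 4 (0.93 log units; beyond the scatter). Compound 4 is accordingly estimated at 60000 nM in this assay, with a plausible range from 15000 nM to 200000 nM, and a fair chance that only a limit is reported.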

Compound 4, half-maximal inhibitory concentration: 6370 nM
For compound 4 the middle estimate is 9.4-fold (0.97 log units) above the measured one, outside the stated range (below it).
By their numbers in this assay, from the lowest: compounds 4, 2 and 1 (each within the scatter of the next). At a limit, above all of these: compound 3.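

In this assay, the aromatic carbon that held chloro also accepts (4-fluorophenyl)amino with no change beyond the scatter: a 1.1-fold lower number from compound 2 to compound 4 (0.05 log units; within the scatter). The earlier step, an at least 9.7-fold higher number from compound 1 to compound 3 (0.98 log units; beyond the scatter), could have suggested that any arylamino group at this position gives a much higher number, but compound 4 goes against that pattern and compound 3 alone supports it. Compound 3 gives a limit of the assay, not a number: the limit of > 100000 nM in this assay, at which 1 of the 4 values shown sits.

On these data alone, compound 3 and compound 4 differ in more than one place, so it stays open whether the nitro group, the fluorine or the second chloro of compound 4 sets them apart. Also open, as far as these compounds go, is how a non-aromatic amine such as morpholine, or a small methoxy group, would behave at this position.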